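Para substituent variation on the chromone series, lyase inhibition

This account rests on a few compounds, and the source may have more. Where it says the series, first, only, none or still open, it means among the compounds named here.

Measured so far:
compound 1, `COc1ccc2c(=O)c(Cn3ccnc3)c(-c3ccc([N+](=O)[O-])cc3)oc2c1`: 9%
compound 2, `COc1ccc2c(=O)c(Cn3ccnc3)c(-c3ccc(Br)cc3)oc2c1`: 29%

Compound 2 stands highest of the two numbers in an assay on isolated protein for inhibition of steroid 17-alpha-hydroxylase/17,20 lyase (Homo sapiens), tested at 2.5 uM; on this read-out higher numbers stand for more inhibition at the one concentration tested (going by the name of the read-out) and lower numbers for less inhibition; compound 1 sits a number 20 percentage points higher from compound 1 to compound 2 (beyond the scatter) away. Compound 3, `COc1ccc2c(=O)c(Cn3ccnc3)c(-c3ccc(C#N)cc3)oc2c1`, differs from compound 2 by cyano in place of bromo on an aromatic carbon. Among the measured compounds shown here, the only measured step that bears on it is the swap of the same group, a number 20 percentage points higher from compound 1 to compound 2 (beyond the scatter), which was modest. With one step to go on, a group between the two measured ones is expected to give a small drop, a number 8 percentage points lower from compound 2 to compound 3 (within the scatter), within the scatter. Compound 3 is estimated at 21%, with a range of 6% to 38%.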

Compound 3, a percentage reported as inhibition, at one concentration (the size of the read-out at that concentration, not a potency): 12%
Estimate against measurement, compound 3: 9 percentage points above, and the stated range covers the measured number.
By their numbers in this assay, from the lowest: compounds 1 and 3 (each within the scatter of the next); then compound 2.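

In this assay, the change from 4-bromophenyl to 4-cyanophenyl gives a number 17 percentage points lower from compound 2 to compound 3 (beyond the scatter) and shows that the higher number of compound 2 is not shared by every replacement at this position. Cyano in place of nitro gives a number 3 percentage points higher from compound 1 to compound 3 (within the scatter) and leaves these two groups indistinguishable here, so bromo alone stands apart among the three. Nothing available explains the difference between bromo and the other two groups. From the compounds shown here alone, whether chloro, methyl or an amine at this place would read with bromo or with cyano and nitro remains open.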